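The source may report more compounds than this note shows. Statements on the series, on what has been measured and on what is new or still open speak of the compounds shown alone.

Three positional isomers of one another make up the measured set. Compound 1 `ClCc1cccc(Cn2cnc3c(Cl)nc(Cl)nc32)c1`, compound 2 `ClCc1ccc(Cn2cnc3c(Cl)nc(Cl)nc32)cc1` and compound 3 `ClCc1ccccc1Cn1cnc2c(Cl)nc(Cl)nc21` share the same core and differ only in the placement of a single substituent. In a functional assay on KM12 cells (Homo sapiens) for cytotoxicity, read by sulforhodamine B assay, with a stated time of 48 h (on this read-out higher numbers stand for weaker inhibition of growth and lower numbers for stronger inhibition of growth), compound 1 gives 1820 nM, compound 2 gives 1820 nM and compound 3 gives 1470 nM. Compound 1 and compound 2 match to the digit and together hold the highest value of the three, while compound 3 sits marginally lower, a gap that lies within the scatter, so no order among the three can be claimed.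

Compound 4 `ClCc1cccc(Cn2cnc3c(Cl)ncnc32)c1` has not been measured. Relative to compound 1 the change is hydrogen in place of chloro on an aromatic carbon. Among the compounds with values here, no measured pair in the set shows a step of this kind, so the expectation rests on compound 1 alone at 1820 nM. The step of a 1.4-fold higher number from compound 1 to compound 4 (0.14 log units; within the scatter) is expected to be small, leaning toward a weaker number in this assay. Compound 4 is estimated at 2500 nM, with a range from 900 nM to 7000 nM.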

Compound 4, concentration for 50% growth inhibition: 3460 nM
Beside the measured number, compound 4's estimate is 1.4-fold (0.14 log units) below it; low and high end bracket the measured number.
By their numbers in this assay, from the lowest: compounds 3, 1, 2 and 4 (each within the scatter of the next, the first and the last beyond it).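

The earlier compounds shown here all carry the chloro group on this aromatic carbon between two ring nitrogen atoms, so they gave no reading of the position itself. Hydrogen in place of chloro here gives a 1.9-fold higher number from compound 1 to compound 4 (0.28 log units; within the scatter), so in this assay the exchange leaves no step beyond the scatter, and this single pair gives no sign that the chloro group at this position is needed for growth inhibition. Nothing on hand bears on what lies behind this result.

The compounds shown leave open how an amine, a methoxy group or a longer chain on this carbon would read in this assay. Also open, from the compounds shown here alone, is whether the same exchange gives a similar step on compound 2 and compound 3, and what happens at the remaining chloro group.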